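The source may hold more compounds than are shown below. What is called first, only, known or untested is meant among the compounds shown, and "the series" means these compounds.

Measured so far in a functional assay on MCF7 cells (Homo sapiens) for cytotoxicity, read by MTT assay, with a stated time of 48 h (on this read-out lower numbers stand for stronger inhibition and higher numbers for weaker inhibition), are three compounds:
- compound 1 `C/C(=N/NC(=S)Nc1ccccc1F)c1ccccn1` gives 0.39 nM here
- compound 2 `CC(=NNC(=S)Nc1ccccc1)c1ccccn1` gives 0.18 nM here
- compound 3 `C/C(=N\NC(=S)Nc1ccccc1F)c1ccccn1` gives 0.39 nM here

Compound 1 stands level with compound 3 at the top of these three numbers, and compound 2 has the lowest value, with the gap to compound 1 lying beyond the scatter.

The next compound is compound 4 `C/C(=N/NC(=S)Nc1ccccc1[N+](=O)[O-])c1ccccn1`, which differs from compound 1 by nitro in place of fluoro on an aromatic carbon, ortho to a large group (nitro in place of fluoro on an aromatic carbon). Among the measured compounds shown here, the only measured step (no change at the digits printed from compound 1 to compound 3 (within the scatter)) rests on the fact that compounds 1 and 3 differ only in the configuration as drawn and so gives no size for an exchange of substituent. For the measured compounds named here, the sole guide is the narrow spread from compound 2 at 0.18 nM to compound 1 at 0.39 nM in this assay, and on that basis no step beyond the scatter is expected. The expected step is estimated as a 1.2-fold higher number from compound 1 to compound 4 (0.06 log units; within the scatter), with no firm direction. For compound 4 the estimated value is 0.45 nM, within an expected range of 0.12 nM to 1.8 nM.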

Compound 4, half-maximal inhibitory concentration: 5.7 nM
Beside the measured number, compound 4's estimate is 13-fold (1.10 log units) below it, outside the stated range (above it).
By their numbers in this assay, from the lowest: compound 2; then compounds 1 and 3 (each within the scatter of the next); then compound 4.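

In this assay, the aromatic carbon ortho to a large group proves sensitive to what it carries: putting nitro in place of fluoro gives a 15-fold higher number from compound 1 to compound 4 (1.16 log units; beyond the scatter), so this exchange weakens inhibition markedly. The earlier compounds could not show this, as their only listed step, no change at the digits printed from compound 1 to compound 3 (within the scatter), concerns configuration as drawn and involves no exchange of substituent. Nothing among the compounds or the available evidence accounts for the size of the new step.

The compounds shown leave open how an amine or a methoxy group on this same carbon would compare with fluoro and nitro. They also leave open whether nitro would give a step of similar size on the double-bond configuration drawn in compound 3.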